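Trifluoromethyl for Fluoro on Two Cores in a Cytotoxicity Assay

This account rests on a few compounds, and the source may have more. Where it says the series, first, only, none or still open, it means among the compounds named here.

Three compounds have been measured in an ADME assay on THP-1 cells (Homo sapiens) for cytotoxicity, read by flow cytometry and propidium iodide staining, with a stated time of 72 h; a higher number here means a weaker inhibitor, a lower number a stronger inhibitor:
Compound 1 `CC(=O)Nc1ccc(O)c(C(=O)/C=C/c2ccc(F)cc2)c1` gives 68800 nM.
Compound 2 `CC(=O)Nc1ccc(O)c(C(=O)/C=C/c2ccc(C(F)(F)F)cc2)c1` gives 15500 nM.
Compound 3 `COc1c(-c2cccc(F)c2)oc2ccc(N)cc2c1=O` gives 34000 nM.

Compound 1 and compound 2 share one core and differ in a single place: trifluoromethyl in place of fluoro on an aromatic carbon. That change gave a 4.4-fold lower number from compound 1 to compound 2 (0.65 log units; beyond the scatter) in this assay.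

Compound 3 rests on a different core; how the two cores differ is not broken down here. Compound 4 `COc1c(-c2cccc(C(F)(F)F)c2)oc2ccc(N)cc2c1=O` has not yet been measured and differs from compound 3 in one place: trifluoromethyl in place of fluoro on an aromatic carbon. Within the data shown here, this is the same kind of change as the one from compound 1 to compound 2, though not the same, for the group sits "para to a large group" in the first pair and "meta to a large group" in the second.

Because the earlier change gave a 4.4-fold lower number from compound 1 to compound 2 (0.65 log units; beyond the scatter), a step of similar direction but somewhat smaller size is expected here, a 3.1-fold lower number from compound 3 to compound 4 (0.49 log units; beyond the scatter). Compound 4 is therefore estimated at 11000 nM in this assay, between 4000 nM and 30000 nM.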

Compound 4, half-maximal inhibitory concentration: 33000 nM
Estimate against measurement, compound 4: 3.0-fold (0.48 log units) below; measured number outside the range, above it.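

In this assay, putting trifluoromethyl in place of fluoro on the core of compound 3 gave a 1.0-fold lower number from compound 3 to compound 4 (0.01 log units; within the scatter) and so left the reading effectively unchanged. A change that counted on one core thus did not carry over in size to the other, which is a reminder that a step seen once cannot simply be added to a new core: the same change on two cores in this assay, a 4.4-fold lower number (0.65 log units; beyond the scatter) from compound 1 to compound 2 and a 1.0-fold lower number (0.01 log units; within the scatter) from compound 3 to compound 4, 4.3-fold (0.63 log units) apart, beyond the scatter of two such steps. The two pairs differ both in their core and in where the group sits, so these data do not show which of the two accounts for the gap, and two pairs set no rule for any other core.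

The compounds shown leave open how other groups in the same place, such as chloro, methoxy or an amine, would read on either core. They also leave open whether the two cores would respond alike if the fluoro and trifluoromethyl groups sat in the same place on both.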